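The source may report more compounds than this note shows. Statements on the series, on what has been measured and on what is new or still open speak of the compounds shown alone.

Working notes on the series.

Among the measured compounds shown here, in a functional assay, read by Griess assay, with a stated time of 150 min, tested at 100 ug/mL (on this read-out lower numbers stand for a weaker effect and higher numbers for a stronger effect at the one concentration tested), compound 2 `COc1ccc(C2=NN(c3ccccc3)C(c3ccc(C)cc3)C2S(=O)(=O)CC2=NCCO2)cc1` gives 70.5%, the only number in hand for this series. Compound 1 `O=S(=O)(CC1=NCCS1)c1n[nH]cc1-c1ccccc1` was reported in this assay as "not active" (no number reported), without a number, so compound 2 stands alone as a point of reference.

Compound 3 `COc1ccc(C2=NN(c3ccccc3)C(c3ccc(C)cc3)C2S(=O)(=O)CC2=NCCS2)cc1` differs from compound 2 by a group of 5 heavy atoms (3 carbon, 1 nitrogen, 1 sulfur; one five-membered non-aromatic ring with 2 hetero atoms) in place of a group of 5 heavy atoms (3 carbon, 1 nitrogen, 1 oxygen; one five-membered non-aromatic ring with 2 hetero atoms), on a saturated chain carbon bound to a sulfonyl sulfur. For the measured compounds named here, no step between two measured compounds is available to size this change. Given the single value of compound 2 in this assay, 70.5%, the step is expected to stay within the usual scatter, with no clear direction.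

Compound 3 is therefore estimated at 68% in this assay, with a range of 50% to 85%, meaning an expected step of a number 2.5 percentage points lower from compound 2 to compound 3 (within the scatter).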

Compound 3, a percentage reported as activity, at one concentration (the size of the read-out at that concentration, not a potency): 50.7%
Compound 3: the middle estimate sits 17.3 percentage points above what was measured; measured number inside the range.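

The ring swap on the saturated chain carbon bound to a sulfonyl sulfur is not neutral in this assay: exchanging the oxygen-containing ring for the sulfur-containing ring gives a number 19.8 percentage points lower from compound 2 to compound 3 (beyond the scatter). Among the compounds shown here, this is the first sign that the read-out responds to this position, and that a single hetero atom in this ring is enough to change it, while the heavy-atom count and the hydrogen-bond counts stay the same. Nothing at hand explains the step.

As far as these compounds go, whether an open-chain amine or a carboxylic acid in place of the ring would retain the read-out stays open. From the compounds shown here alone, whether the step holds on other cores also remains unknown.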